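Removing one methoxy from the aryl ester of compound 3

The source may hold more compounds than are shown below. What is called first, only, known or untested is meant among the compounds shown, and "the series" means these compounds.

In a functional assay on HT-29 cells (Homo sapiens) for antiproliferative activity, read by sulforhodamine B assay, with a stated time of 48 h (on this read-out higher numbers stand for weaker inhibition and lower numbers for stronger inhibition), compound 3 `CCCN1CCN(c2ccc(S(=O)(=O)Oc3ccc(OC)c(OC)c3)cc2)C1=O` gives 14000 nM and compound 2 `CCCN1CCN(c2ccc(S(=O)(=O)Oc3ccc(C)cc3C)cc2)C1=O` gives 26000 nM; these two values lie within the scatter of each other. Compound 1 `COc1ccc(OS(=O)(=O)c2ccc(N3CCN(C)C3=O)cc2)cc1` reads > 100000 nM in this assay, which is a limit of the assay and not a number.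

Compound 4 `CCCN1CCN(c2ccc(S(=O)(=O)Oc3ccc(OC)cc3)cc2)C1=O` carries hydrogen in place of methoxy on an aromatic carbon, ortho to a methoxy group and meta to a large group: hydrogen in place of methoxy on an aromatic carbon. For the measured compounds named here, no measured pair isolates this change, so the expectation rests on little. Compound 2 at 26000 nM and compound 3 at 14000 nM stay within the scatter despite their different ring substituents, so a modest move toward a higher number in this assay is expected, possibly no larger than the scatter. The estimated change is a 1.6-fold higher number from compound 3 to compound 4 (0.20 log units; within the scatter). The expected value for compound 4 is 22000 nM, with an estimated range of 8000 nM to 60000 nM.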

Compound 4, half-maximal inhibitory concentration: 16000 nM
Beside the measured number, compound 4's estimate is 1.4-fold (0.14 log units) above it, within the range that was stated.
By their numbers in this assay, from the lowest: compounds 3, 4 and 2 (each within the scatter of the next). At a limit, above all of these: compound 1.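

Replacing the methoxy that sits ortho to a methoxy group and meta to a large group with hydrogen makes no change that can be read in this assay (a 1.1-fold higher number from compound 3 to compound 4 (0.06 log units; within the scatter)), so the second methoxy is not needed at this position to keep the activity seen here. Changing the whole aryl group, with 4-methoxyphenyl in place of 2,4-dimethylphenyl, also stays within the scatter (a 1.6-fold lower number from compound 2 to compound 4 (0.21 log units; within the scatter)). The only step beyond the scatter is ethyl in place of hydrogen on a saturated chain carbon bound to an amide-type nitrogen in a ring (an at least 6.2-fold lower number from compound 1 to compound 4 (0.79 log units; beyond the scatter)), and it can be read only as a bound, since compound 1 stands at a limit and not at a number: the limit of > 100000 nM in this assay, at which 1 of the 4 values shown sits.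

Going by these compounds, whether this aromatic carbon also accepts an amine or a carboxylic acid stays open. So does the effect of a longer chain on the amide-type nitrogen than the one in compound 4.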